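Replacing Dimethylamino with Amino on a Thiocarbonyl Carbon

A few compounds are considered here, and "the series" means these few. Any claim that something is new, unique, unknown or untested is made for them only; others in the source may bear on it.

Compound 1, `CN(C)C(=S)N/N=C/c1ccc2ccccc2n1`, gives 20 nM in a functional assay on HT-29 cells (Homo sapiens) for antiproliferative activity, read by sulforhodamine B assay, with a stated time of 72 h; on this read-out lower numbers stand for stronger inhibition and higher numbers for weaker inhibition.
Compound 2, `NC(=S)N/N=C/c1ccc2ccccc2n1`, gives 100000 nM in this assay.
Compound 3, `CN(C)C(=S)N/N=C/c1cnc2ccccc2n1`, gives 450 nM in this assay.

Compounds 1 and 2 share one core and differ in a single place: amino in place of dimethylamino on a thiocarbonyl carbon. That change produced a 5000-fold higher number from compound 1 to compound 2 (3.70 log units; beyond the scatter), a large weakening. Compound 3 sits on a different core; how the core of compound 3 differs from the core of compound 1 is not broken down here, and the two values show compound 3 standing well above compound 1 and well below compound 2.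

Compound 4, `NC(=S)N/N=C/c1cnc2ccccc2n1`, has not yet been measured. It differs from compound 3 in exactly the same way, (amino in place of dimethylamino on a thiocarbonyl carbon), and the surroundings of the change are the same in both pairs. Because the earlier change gave a 5000-fold higher number from compound 1 to compound 2 (3.70 log units; beyond the scatter), compound 4 is expected to fall far behind compound 3, with a step estimated at a 220-fold higher number from compound 3 to compound 4 (2.35 log units; beyond the scatter). Compound 4 is accordingly expected to give about 100000 nM in this assay, likely between 20000 nM and 200000 nM.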

Compound 4, half-maximal inhibitory concentration: > 100000 nM
Compound 4: no number, only a limit (the forecaster's own chance of this, stated with the estimate: 30%); the middle value sits exactly at the limit.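

In this assay compound 4 gives > 100000 nM, which is a limit of the assay and not a number. Amino in place of dimethylamino on a thiocarbonyl carbon thus weakens the result on the core of compound 3 as well, with an at least 220-fold higher number from compound 3 to compound 4 (2.34 log units; beyond the scatter), so the direction of the change carries over from one core to the other in these two pairs. How far the size of the step carries over is not shown, and the two steps cannot be ranked against each other: the same change on two cores in this assay, a 5000-fold higher number (3.70 log units; beyond the scatter) from compound 1 to compound 2 and an at least 220-fold higher number (2.34 log units; beyond the scatter) from compound 3 to compound 4; the limit leaves it open whether they differ

The compounds shown carry only dimethylamino and amino at this place, so it remains open where methylamino, ethylamino or diethylamino would stand in this assay. On these data alone, it also remains open whether the same change would weaken the result to a similar degree on any core other than these two.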